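Stretching a Methoxy into a Butoxy

This account rests on a few compounds, and the source may have more. Where it says the series, first, only, none or still open, it means among the compounds named here.

This small series is followed in a functional assay on HepG2 cells (Homo sapiens) for antiproliferative activity, read by sulforhodamine B assay, with a stated time of 3 days; a lower number here means that less compound is needed, a higher number that more compound is needed for the effect. Compound 1 `CCCC1=C(OC)C(CCC)(CCC)C(=O)/C(=C(O)\C=C\c2ccccc2)C1=O` offers no anchor, because its entry reads "not determined" (no result reported) and no number exists for it. Two relatives do carry numbers. Compound 2 `CCCC1=C(OC)C(CCC)(CCC)C(=O)/C(=C(O)\C=C\c2ccc(I)cc2)C1=O` gives 2.4 uM and compound 3 `COC1=C(CC(C)C)C(=O)/C(=C(O)/C=C/c2ccccc2)C(=O)C1(CC(C)C)CC(C)C` gives 14.5 uM, so compound 3 needs more material for the same effect.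

The next structure, compound 4 `CCCCOC1=C(CCC)C(=O)/C(=C(O)/C=C/c2ccccc2)C(=O)C1(CCC)CCC`, comes from compound 1 through a single edit. That edit is propyl in place of hydrogen on a saturated chain carbon bound to an oxygen on an unsaturated carbon, which turns the methoxy into a butoxy.

Among the compounds with values here, no measured step shows what this edit does, since compound 1 has no value to start from. In this assay the expectation is therefore a step no larger than the usual scatter, with neither direction favoured. Within the data shown here, the only guidance comes from the two measured relatives, and the expectation leans toward the higher of them, compound 3 at 14.5 uM.

For compound 4 the expected concentration for half-maximal effect is 10 uM, with an estimated range from 3 uM to 30 uM.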

Compound 4, concentration for half-maximal effect: 8 uM
Compound 4: middle estimate off by 1.3-fold (0.10 log units), on the high side; the measured number falls inside the stated range.
By their numbers in this assay, from the lowest: compound 2; then compounds 4 and 3 (each within the scatter of the next).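

Within the data shown here, no step can be read from compound 1 to compound 4, the only pair here that differs in one place: of the two, only compound 4 carries a number in this assay. From the compounds shown here alone, what stretching the methoxy into a butoxy does to the concentration needed therefore stays open. Nothing measured here offers an explanation for the value of compound 4.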